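Swapping the Chain Tip of Compound 2

The source may report more compounds than this note shows. Statements on the series, on what has been measured and on what is new or still open speak of the compounds shown alone.

In a functional assay on the whole organism with Rattus norvegicus as the target, with a stated time of 4 h, at a dose of 40 mg/kg by the intraperitoneal route (a lower number here means less inhibition, a higher number more inhibition at the dose given (going by the name of the read-out)), compound 1, `Cc1cn2cccc(OCc3ccccc3)c2n1`, gives 62%. Within the data shown here, compound 2, `[C-]#[N+]Cc1c(C)nc2c(OCc3ccccc3)cccn12`, gives 96%, the higher of the two numbers measured so far. The step of a number 34 percentage points higher from compound 1 to compound 2 (beyond the scatter) came with a group of 3 heavy atoms (2 carbon, 1 nitrogen; no ring) in place of a hydrogen atom, on an aromatic carbon. Compound 3, `Cc1nc2c(OCc3ccccc3)cccn2c1C[S+](C)[O-]`, has not yet been measured. It differs from compound 2 in one place: a group of 3 heavy atoms (1 carbon, 1 oxygen, 1 sulfur; no ring) in place of a group of 2 heavy atoms (1 carbon, 1 nitrogen; no ring), on a saturated chain carbon bound to an aromatic carbon. Among the measured compounds shown here, the one measured step added the whole chain rather than changing its end, so it gives no direct guide to this swap. For the measured compounds named here, with a very high starting number and no comparable step, a moderate downward change is expected, a number 21 percentage points lower from compound 2 to compound 3 (beyond the scatter), with wide uncertainty. Compound 3 is estimated at 75%, within a range from 40% to 97%.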

Compound 3, a percentage reported as inhibition, in the whole organism at one dose (the size of the read-out at that dose, not a potency): 0%
Beside the measured number, compound 3's estimate is 75 percentage points above it; the whole stated range lies above it.
By their numbers in this assay, from the lowest: compound 3; then compound 1; then compound 2.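

In this assay, the tip of the chain on this saturated chain carbon decides the outcome, not just the presence of a chain: with the group of 1 carbon, 1 oxygen and 1 sulfur in place of the group of 1 carbon and 1 nitrogen with its triple bond, the result is a number 96 percentage points lower from compound 2 to compound 3 (beyond the scatter). The new tip also leaves the whole chain as a loss rather than a gain against the chainless compound, with a number 62 percentage points lower from compound 1 to compound 3 (beyond the scatter), so this position can either raise the number or wipe it out. Nothing measured here explains this loss.

With only two chain tips shown, it stays open whether sulfur, oxygen or the whole group carries the loss. As far as these compounds go, how an amine, a carboxylic acid or a longer chain would behave at this position also remains unknown.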